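Dichloro for fluoro on the triazole phenyl

The compounds below may be only part of what the source reports. "The series", "measured", "known", "first", "only" and "open" are said of these compounds alone.

Measured compounds in a functional assay on HT-29 cells (Homo sapiens) for cytotoxicity, read by MTT assay, with a stated time of 72 h; a higher number here means a weaker inhibitor, a lower number a stronger inhibitor:
compound 1 `COc1cc2c(Oc3ccc(NC(=O)c4cn(-c5ccccc5Cl)nn4)cc3F)ccnc2cc1OCCCN1CCCC1` gives 150 nM;
compound 2 `COc1cc2c(Oc3ccc(NC(=O)c4cn(-c5c(C)cccc5C)nn4)cc3F)ccnc2cc1OCCCN1CCCC1` gives 2240 nM;
compound 3 `COc1cc2c(Oc3ccc(NC(=O)c4cn(-c5ccccc5F)nn4)cc3F)ccnc2cc1OCCCN1CCCCC1` gives 290 nM.

Among these three numbers compound 3 stands second highest, close to compound 1 and within the scatter of it, while compound 2 lies well beyond the scatter on the higher side. Compound 4 `COc1cc2c(Oc3ccc(NC(=O)c4cn(-c5c(Cl)cccc5Cl)nn4)cc3F)ccnc2cc1OCCCN1CCCCC1` differs from compound 3 only in 2,6-dichlorophenyl in place of 2-fluorophenyl on an aromatic nitrogen. For the measured compounds named here, one measured step bears on this: the phenyl on the aromatic nitrogen changed from 2-chlorophenyl to 2,6-dimethylphenyl, giving a 15-fold higher number from compound 1 to compound 2 (1.17 log units; beyond the scatter). The change from compound 3 to compound 4 is of the same kind, so a clearly higher number is expected for compound 4, an estimated 6.9-fold higher number from compound 3 to compound 4 (0.84 log units; beyond the scatter). Compound 4 is therefore estimated at 2000 nM, with a range from 600 nM to 6500 nM.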

Compound 4, half-maximal inhibitory concentration: 240 nM
For compound 4 the middle estimate is 8.3-fold (0.92 log units) above the measured one, and the stated range ends above it.
By their numbers in this assay, from the lowest: compounds 1, 4 and 3 (each within the scatter of the next); then compound 2.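

In this assay the step of a 1.2-fold lower number from compound 3 to compound 4 (0.08 log units; within the scatter) shows that 2,6-dichlorophenyl can stand in place of 2-fluorophenyl on the aromatic nitrogen with no change beyond the scatter. The large earlier step of a 15-fold higher number from compound 1 to compound 2 (1.17 log units; beyond the scatter) therefore does not hold for every exchange at this position, and a second group on the phenyl does not by itself bring such a loss. Nothing available explains why these two steps differ.

Going by these compounds, compound 2 and compound 4 differ in more than one place, so how 2,6-dimethylphenyl and 2,6-dichlorophenyl compare directly stays open. Also open, on these data alone, is what a phenyl carrying a methoxy group or an amine would give here.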